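Carbamate in place of the difluorobenzamide on the shared core

The source may report more compounds than this note shows. Statements on the series, on what has been measured and on what is new or still open speak of the compounds shown alone.

Measured so far in a physicochemical assay for lipophilicity, at pH 7.4; a higher number here means a more lipophilic compound, a lower number a more polar compound:
Compound 1, `Cc1cc(C(=O)NCc2ccccn2)nn1Cc1cc(Cl)ccc1OCc1ccccc1`, gives a limit of the assay, > 3.7.
Compound 2, `CC(=O)Nc1cc(C)n(Cc2cc(Cl)ccc2OCc2ccccc2)n1`, also gives only a limit, > 3.7.
Compound 3, `Cc1cc(NC(=O)c2c(F)cccc2F)nn1Cc1cc(Cl)ccc1OCc1ccccc1`, likewise gives only a limit, > 3.7.

Compound 3 therefore stands at the upper limit, as do the other two values shown (the limit of > 3.7 in this assay, at which 3 of the 3 values shown sit). For the measured compounds named here, no measured step leads to compound 4; instead compound 4, `Cc1cc(NC(=O)OCc2ccccn2)nn1Cc1cc(Cl)ccc1OCc1ccccc1`, differs from compound 3 by (pyridin-2-yl)methoxy in place of 2,6-difluorophenyl on a carbonyl carbon. The measured steps a step that the two limits leave unreadable from compound 1 to compound 3, a step that the two limits leave unreadable from compound 2 to compound 3 and a step that the two limits leave unreadable from compound 1 to compound 2 are all unreadable, so no size for a comparable change can be taken from them. Compound 4 is expected to fall somewhat, to about 3.6 (range 3 to 4.2). The expected step is a number at least 0.10 log units lower from compound 3 to compound 4 (that floor lies within the scatter).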

Compound 4, distribution coefficient: 3.1
The estimate for compound 4 lay 0.50 log units above the measured number, within the range that was stated.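

In this assay, compound 4 is the only compound shown that gives a number rather than a limit: the limit of > 3.7 in this assay, at which 3 of the 4 values shown sit.

On a carbonyl carbon, (pyridin-2-yl)methoxy in place of 2,6-difluorophenyl gives a number at least 0.60 log units lower from compound 3 to compound 4 (beyond the scatter), and in place of methyl it gives a number at least 0.60 log units lower from compound 2 to compound 4 (beyond the scatter). On an aromatic carbon, (((pyridin-2-yl)methoxy)carbonyl)amino in place of ((pyridin-2-yl)methyl)carbamoyl gives a number at least 0.60 log units lower from compound 1 to compound 4 (beyond the scatter), while the steps among the three earlier compounds cannot be read.

From the compounds shown here alone, the full size of each new step stays open, as does any order among the groups replaced. A phenylmethoxy group on the same carbonyl carbon would separate the contribution of the pyridine nitrogen from that of the carbamate oxygen.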